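This account rests on a few compounds, and the source may have more. Where it says the series, first, only, none or still open, it means among the compounds named here.

Three related compounds share one core, and each has been tested in an ADME assay on SH-SY5Y cells (Homo sapiens) for cytotoxicity, read by MTT assay, with a stated time of 48 h; a higher number here means a weaker inhibitor, a lower number a stronger inhibitor. Compound 1, `COc1ccc(C(=O)/C=C/c2ccc(C(=O)N(C)c3ccccc3)cc2)c(O)c1`, gives in this assay only a limit, > 100000 nM. Compound 2, `COc1ccc(C(=O)/C=C/c2cc(OC)c(OC)c(OC)c2)c(O)c1`, likewise reaches only the limit of this assay, > 100000 nM. Compound 3, `COc1ccc(C(=O)/C=C/c2ccc(OCCCOc3ccccc3)c(OC)c2)c(O)c1`, gives the same kind of result in this assay, a limit of > 100000 nM. So all three sit at the same point, the assay limit described by the limit of > 100000 nM in this assay, at which 3 of the 3 values shown sit, and none of them can be ranked against the others.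

Compound 4, `COc1ccc(C(=O)/C=C/c2ccc(C(=O)Nc3ccc(C)cc3C)cc2)c(O)c1`, is the next compound to be tested. It differs from compound 1 in one place: (2,4-dimethylphenyl)amino in place of methyl(phenyl)amino on a carbonyl carbon. For the measured compounds named here, with compound 1 resting at a limit rather than a number, no measured step shows how far a change of this kind moves the result in this assay. The expectation is therefore that compound 4 will also show a step that the limit leaves unreadable from compound 1 to compound 4, nothing beyond the scatter. Compound 4 is thus expected to give about 150000 nM in this assay, with a plausible range from 50000 nM to 500000 nM, most likely again reported only as a limit.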

Compound 4, half-maximal inhibitory concentration: > 100000 nM
Compound 4: no number, only a limit; the forecaster's own chance of this, stated with the estimate: 80%; the middle value does not contradict the limit.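

Compound 1 and compound 4 both give only a limit in this assay, so no step can be read between them. The compounds shown leave open how they rank against one another and whether any change would give a measurable number, since all rest at one point: the limit of > 100000 nM in this assay, at which 4 of the 4 values shown sit.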